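Replacing piperazin-1-yl with methylamino on the shared core

A few compounds are considered here, and "the series" means these few. Any claim that something is new, unique, unknown or untested is made for them only; others in the source may bear on it.

Measured in a functional assay on MDA-MB-435 cells (Homo sapiens) for cytotoxicity, read by MTT assay, with a stated time of 72 h; on this read-out lower numbers stand for stronger inhibition and higher numbers for weaker inhibition:
- Compound 1 `Nc1cccc(Nc2c(C(=O)NCc3ccc(F)cc3)nc(Br)c3cccnc23)c1`: 8000 nM
- Compound 2 `O=C(NCc1ccc(F)cc1)c1nc(Br)c2cccnc2c1N1CCNCC1`: 8000 nM

Among the measured compounds shown here, compound 2 stands level with the only other measured compound. Compound 3 `CNc1c(C(=O)NCc2ccc(F)cc2)nc(Br)c2cccnc12` differs from it in one place: methylamino in place of piperazin-1-yl on an aromatic carbon. Methylamino takes the place of piperazin-1-yl on an aromatic carbon. For the measured compounds named here, one measured step bears on this carbon, no change at the digits printed from compound 1 to compound 2 (within the scatter), so exchanging these two groups left the reading unmoved. Methylamino itself is untested, and a single step is thin evidence. In this assay, the expected step, none beyond the scatter, is no change at the digits printed from compound 2 to compound 3 (within the scatter). Compound 3 is estimated at 8000 nM, with an expected range of 3000 nM to 20000 nM.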

Compound 3, half-maximal inhibitory concentration: > 20000 nM
Compound 3 was reported as a limit (the forecaster's own chance of this, stated with the estimate: 15%); at least 2.5-fold (0.39 log units) between middle value and limit.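

In this assay the reading of compound 3 is a limit and not a number: the limit of > 20000 nM in this assay, at which 1 of the 3 values shown sits. Methylamino gives an at least 2.5-fold higher number from compound 2 to compound 3 (0.39 log units; beyond the scatter) and an at least 2.5-fold higher number from compound 1 to compound 3 (0.39 log units; beyond the scatter), so this aromatic carbon does not accept every amine alike, even though piperazin-1-yl and (3-aminophenyl)amino read the same there. How far compound 3 really lies beyond the limit stays unknown, and the three compounds do not explain the loss. On these data alone, whether ethylamino or morpholin-4-yl at this carbon would read like compound 2 or like compound 3 also remains open.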